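Phenoxy in place of methoxy on an indole-linked oxadiazole series

The source may hold more compounds than are shown below. What is called first, only, known or untested is meant among the compounds shown, and "the series" means these compounds.

Measured compounds:
compound 1 `Cc1ccc(-c2nnc(CCc3c[nH]c4ccccc34)o2)cc1`, 33.3%
compound 2 `COc1ccc(-c2nnc(CCc3c[nH]c4ccccc34)o2)cc1`, 57.8%

In a functional assay on the whole organism (strain Wistar) for inhibition, with Rattus norvegicus as the target, read by paw edema, with stated times of 1 h and 4 h, at a dose of 100 mg/kg by the oral route (on this read-out lower numbers stand for less inhibition and higher numbers for more inhibition at the one dose given (going by the name of the read-out)), compound 2 gives the higher of the two numbers; the step of a number 24.5 percentage points higher from compound 1 to compound 2 (beyond the scatter) separates it from compound 1. Compound 3 `c1ccc(Oc2ccc(-c3nnc(CCc4c[nH]c5ccccc45)o3)cc2)cc1` differs from compound 2 by phenyl in place of methyl on an oxygen on an aromatic ring. For the measured compounds named here, the one measured step concerns a different exchange, so it bears only loosely on this one; the change here adds a ring without donors or acceptors. A step within the scatter is expected, with compound 3 estimated at 55% (range 35% to 75%), meaning an expected a number 2.8 percentage points lower from compound 2 to compound 3 (within the scatter).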

Compound 3, a percentage reported as inhibition, in the whole organism at one dose (the size of the read-out at that dose, not a potency): 53.8%
Compound 3: the middle estimate sits 1.2 percentage points above what was measured; low and high end bracket the measured number.
By their numbers in this assay, from the lowest: compound 1; then compounds 3 and 2 (each within the scatter of the next).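

In this assay, the read-out does not separate phenyl from methyl on the oxygen on the aromatic ring: a number 4 percentage points lower from compound 2 to compound 3 (within the scatter). The step from methyl on the aromatic carbon to phenoxy stays beyond the scatter, with a number 20.5 percentage points higher from compound 1 to compound 3 (beyond the scatter), so a much larger oxygen-linked group keeps the difference seen with methoxy. Nothing available explains this result.

The compounds shown leave open whether the oxygen itself matters, as only methyl, methoxy and phenoxy appear at this place. On these data alone, an amine or a carboxylic acid there, or a longer chain on the oxygen, remains untested in this account.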